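The source may report more compounds than this note shows. Statements on the series, on what has been measured and on what is new or still open speak of the compounds shown alone.

In a functional assay on NCI-H1581 cells (Homo sapiens) for antiproliferative activity, read by CCK-8 assay, with a stated time of 72 h (a higher number here means a weaker inhibitor, a lower number a stronger inhibitor), three compounds sharing one core have been measured. Compound 1 (`COc1cc(OC)c(Cl)c(-c2ccc3c(NC(=O)c4ccc(C5CCN(C)CC5)cc4)n[nH]c3n2)c1Cl`) gives 8.2 nM, compound 2 (`COc1cc(OC)c(Cl)c(-c2ccc3c(NC(=O)c4ccc(N5CCCN(C)CC5)cc4)n[nH]c3n2)c1Cl`) gives 1.3 nM, and compound 3 (`COc1cc(OC)c(Cl)c(-c2ccc3c(NC(=O)c4ccc(N5CCN(C)CC5)s4)n[nH]c3n2)c1Cl`) gives 3.7 nM, which places compound 3 in the middle of the three. Compound 4 (`COc1cc(OC)c(Cl)c(-c2ccc3c(NC(=O)c4ccccc4)n[nH]c3n2)c1Cl`) differs from compound 3 by one change: a group of 6 heavy atoms (6 carbon; one six-membered aromatic ring of carbon only) in place of a group of 12 heavy atoms (9 carbon, 2 nitrogen, 1 sulfur; one five-membered aromatic ring with 1 hetero atom, one six-membered non-aromatic ring with 2 hetero atoms), on a carbonyl carbon. Among the measured compounds shown here, the only measured step that bears on this, a 6.3-fold lower number from compound 1 to compound 2 (0.80 log units; beyond the scatter), exchanged one ring for another and was modest, yet it shows that numbers respond to changes in this part of the molecule. Compound 4 gives up far more, so a larger step towards a higher number, meaning a weaker inhibitor, is expected. The expected step is a 16-fold higher number from compound 3 to compound 4 (1.21 log units; beyond the scatter). For compound 4 the estimated value is 60 nM, with a range of 12 nM to 300 nM.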

Compound 4, half-maximal inhibitory concentration: > 1000 nM
Compound 4 was reported as a limit; the forecaster's own chance of this, stated with the estimate: 5%; middle value at least 16-fold (1.22 log units) away from the limit.
By their numbers in this assay, from the lowest: compound 2; then compound 3; then compound 1. At a limit, above all of these: compound 4.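

In this assay compound 4, with a bare phenyl on the carbonyl carbon, is reported only as a limit: the limit of > 1000 nM in this assay, at which 1 of the 4 values shown sits. Hydrogen on the aromatic carbon gives (an at least 120-fold higher number from compound 1 to compound 4 (2.08 log units; beyond the scatter)) in place of 1-methylpiperidin-4-yl and (an at least 760-fold higher number from compound 2 to compound 4 (2.88 log units; beyond the scatter)) in place of 4-methyl-1,4-diazepan-1-yl, and phenyl replacing the whole group of compound 3 gives (an at least 270-fold higher number from compound 3 to compound 4 (2.43 log units; beyond the scatter)). Among these compounds, then, having such a ring-and-amine group matters far more than which one it is. From the compounds shown here alone, whether an open-chain amine such as dimethylaminoethyl, or a ring without nitrogen such as cyclohexyl, would recover the activity remains open.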